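A Dimethylcarbamoyl Extension of the Ethoxy Chain

A few compounds are considered here, and "the series" means these few. Any claim that something is new, unique, unknown or untested is made for them only; others in the source may bear on it.

Of the compounds shown here, three have been measured in an assay for inhibition of serine/threonine-protein kinase Sgk1 (Homo sapiens), with stated times of 30 min and 60 min, in the presence of a further agent that is not named here; a higher number here means a weaker inhibitor, a lower number a stronger inhibitor. Compound 1 `O=C(N[C@@H]1CCNC1)c1cc(-c2ccc(NS(=O)(=O)c3cccc(Cl)c3Cl)cc2)nc2[nH]ncc12` gives < 1 nM, which is a limit of the assay and not a number. Compound 2 `CCN1CCC(CNC(=O)c2cc(-c3ccc(NS(=O)(=O)c4cccc(Cl)c4Cl)cc3)nc3[nH]ncc23)C1` also gives < 1 nM, again a limit. Both values sit at the limit of < 1 nM in this assay, at which 2 of the 3 values shown sit, so the step that the two limits leave unreadable from compound 1 to compound 2 cannot be read, and nothing about its size is known.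

Among the compounds with values here, compound 3 `CCOc1nc(-c2ccc(NS(=O)(=O)c3cc(Cl)ccc3F)cc2)nc2[nH]nc(C)c12` is the only compound with a number: in this assay compound 3 gives 23 nM. It therefore stands alone as the sole readable point, with the two other values being limits.

The untested compound 4 `Cc1n[nH]c2nc(-c3ccc(NS(=O)(=O)c4cc(Cl)ccc4F)cc3)nc(OCCC(=O)N(C)C)c12` differs from compound 3 in one place: dimethylcarbamoyl in place of hydrogen on a saturated chain carbon, two bonds along the chain from an oxygen on an aromatic ring. Within the data shown here, no measured step bears on this change. Among the measured compounds shown here, the only step between measured compounds concerns an amide-type nitrogen elsewhere in the structure and is itself unreadable, so no precedent for lengthening the ethoxy chain is available.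

The expectation for compound 4 accordingly rests on compound 3 alone. The step expected is a 1.2-fold lower number from compound 3 to compound 4 (0.06 log units; within the scatter), small enough to fall within the usual scatter. Compound 4 is thus estimated at 20 nM, within a range from 5 nM to 80 nM.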

Compound 4, half-maximal inhibitory concentration: 15 nM
The estimate for compound 4 lay 1.3-fold (0.12 log units) above the measured number; the range from low to high includes it.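

Within the data shown here, the step of a 1.5-fold lower number from compound 3 to compound 4 (0.19 log units; within the scatter) in this assay gives the first reading at this position, and it shows that the two compounds cannot be told apart there. The earlier compounds shown here held no step at this place, whereas this pair shows that ethoxy can become 2-(dimethylcarbamoyl)ethoxy, with the rest of the structure unchanged, while the reading stays within the scatter. The chain carbon named in this change, two bonds along the chain from an oxygen on an aromatic ring, therefore carries dimethylcarbamoyl with no readable effect on the number, though nothing measured here gives a reason for that outcome.

The compounds shown leave open whether a carboxylic acid, a primary amide or a dimethylamino group at the end of the same chain, or a longer chain carrying the dimethylcarbamoyl group, would also read alike in this assay. They also leave open whether the same change would hold on the core of compound 1 and compound 2, whose values are limits of the assay and whose step between them cannot be read.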